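The source may hold more compounds than are shown below. What is called first, only, known or untested is meant among the compounds shown, and "the series" means these compounds.

Compound 1 `COc1ccc([C@@H]2C/C(=N\O)c3c(O)cc(OCc4cn(C5CCCC5)nn4)cc3O2)cc1O` carries an oxime on its shared core and a cyclopentyl on the aromatic nitrogen of its triazole. In a functional assay on RAW264.7 cells (Mus musculus) for inhibition, read by Griess assay, with stated times of 2 h and 24 h (on this read-out higher numbers stand for weaker inhibition and lower numbers for stronger inhibition), compound 1 gives 6880 nM, the lowest of the three numbers measured. The two ketone analogues sit higher: compound 2 `COc1ccc([C@@H]2CC(=O)c3c(O)cc(OCc4cn(Cc5ccccc5C#N)nn4)cc3O2)cc1O` gives 14600 nM, and compound 3 `COc1ccc([C@@H]2CC(=O)c3c(O)cc(OCc4cn(Cc5cccc(Cl)c5)nn4)cc3O2)cc1O` gives 18200 nM. For the measured compounds named here, the only step between measured neighbours is a 1.2-fold higher number from compound 2 to compound 3 (0.10 log units; within the scatter), so the one change seen so far, which exchanges an aryl group on a saturated chain carbon bound to an aromatic nitrogen, leaves the number essentially where it was.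

Compound 4 `CCCn1cc(COc2cc(O)c3c(c2)O[C@H](c2ccc(OC)c(O)c2)C/C3=N\O)nn1` keeps the oxime and the whole core of compound 1 and differs only at the triazole nitrogen: propyl in place of cyclopentyl on an aromatic nitrogen. Going by the values given here, no measured pair changes the group on the aromatic nitrogen itself, and no pair compares a ring with an open chain, so the data give no direct guide. Among the compounds with values here, the one step that has been measured at the periphery of the triazole is within the scatter, and a swap of cyclopentyl for propyl is a small change of the same kind, so a step no larger than the scatter is expected, in either direction. Compound 4 is therefore estimated at 8000 nM, in a range from 3500 nM to 18000 nM, an expected 1.2-fold higher number from compound 1 to compound 4 (0.07 log units; within the scatter).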

Compound 4, half-maximal inhibitory concentration: 2340 nM
Estimate against measurement, compound 4: 3.4-fold (0.53 log units) above; measured number below the stated range.
By their numbers in this assay, from the lowest: compound 4; then compound 1; then compounds 2 and 3 (each within the scatter of the next).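

In this assay, the step to propyl on the aromatic nitrogen of the triazole is a 2.9-fold lower number from compound 1 to compound 4 (0.47 log units; beyond the scatter), so with the oxime and the rest of the core held constant, the group at this position does move the number beyond the scatter. For the compounds shown here, this differs from the only earlier step, a 1.2-fold higher number from compound 2 to compound 3 (0.10 log units; within the scatter), which exchanged one aryl group for another further out on a saturated chain carbon and stayed within the scatter. The change swaps a five-membered ring of carbon only for an open chain and also reduces the heavy atoms from five to three, and nothing measured here separates the loss of the ring from the reduction in size or offers an explanation for the step.

The compounds shown leave open whether a shorter chain such as ethyl, a longer chain such as butyl or pentyl, or a branched isopropyl group would lower the number further or raise it again, and whether a chain ending in an amine or a carboxylic acid would be tolerated on this nitrogen. They also leave open whether propyl would give a step of similar size on the ketone form of the core, where only aryl-bearing groups appear.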